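Swapping the anilino ring of compound 3 for a 2-chlorophenyl

The source may report more compounds than this note shows. Statements on the series, on what has been measured and on what is new or still open speak of the compounds shown alone.

Compound 1 `Cc1ccc(Cn2cc(CSc3nc(Nc4ccccc4C)c(C#N)c(-c4ccccc4)n3)nn2)cc1`: in a functional assay on ECa-109 cells (Homo sapiens) for inhibition, read by MTT assay, with a stated time of 72 h (a lower number here means a stronger inhibitor, a higher number a weaker inhibitor), compound 1 gives > 64000 nM, which is a limit of the assay.
Compound 2 `Cc1ccc(Cn2cc(CSc3nc(Nc4ccccc4F)c(C#N)c(-c4ccccc4)n3)nn2)cc1`: in this assay compound 2 gives > 64000 nM, also a limit of the assay.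
Compound 3 `Cc1ccc(Cn2cc(CSc3nc(Nc4ccc(C)cc4)c(C#N)c(-c4ccccc4)n3)nn2)cc1`: in this assay compound 3 gives 55700 nM.

Compound 3 is the only one of the three with an actual number; the other two values sit at a limit (the limit of > 64000 nM in this assay, at which 2 of the 3 values shown sit). The steps of an at least 1.1-fold lower number from compound 1 to compound 3 (0.06 log units; that floor lies within the scatter) and an at least 1.1-fold lower number from compound 2 to compound 3 (0.06 log units; that floor lies within the scatter) are floors that lie within the scatter, and the step that the two limits leave unreadable from compound 1 to compound 2 cannot be read at all. Compound 4 `Cc1ccc(Cn2cc(CSc3nc(Nc4ccccc4Cl)c(C#N)c(-c4ccccc4)n3)nn2)cc1` differs from compound 3 by 2-chlorophenyl in place of 4-methylphenyl on a nitrogen on an aromatic ring. Compounds 1 and 2, which carry a 2-methylphenyl or a 2-fluorophenyl group on that same nitrogen, both sit at the limit (the limit of > 64000 nM in this assay, at which 2 of the 3 values shown sit), and on that basis compound 4 is expected to drift back toward a higher number, a step of a 1.3-fold higher number from compound 3 to compound 4 (0.10 log units; within the scatter). Compound 4 is estimated at 70000 nM, with a likely range from 30000 nM to 200000 nM.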

Compound 4, half-maximal inhibitory concentration: 11200 nM
Beside the measured number, compound 4's estimate is 6.3-fold (0.80 log units) above it; the measured number lies below the stated range.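

Which group sits on this nitrogen matters more than the earlier compounds could show: 2-chlorophenyl in place of 4-methylphenyl gives the first fully measured step beyond the scatter (a 5.0-fold lower number from compound 3 to compound 4 (0.70 log units; beyond the scatter)). On the same aromatic carbon, chloro also outdoes fluoro (an at least 5.7-fold lower number from compound 2 to compound 4 (0.75 log units; beyond the scatter)) and methyl (an at least 5.7-fold lower number from compound 1 to compound 4 (0.75 log units; beyond the scatter)), so the group at that one spot separates these otherwise identical compounds. Those last two steps are only floors, set by a limit of the assay: (the limit of > 64000 nM in this assay, at which 2 of the 4 values shown sit).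

As far as these compounds go, whether 2-bromophenyl or 2-methoxyphenyl would go further remains open. So does how 4-chlorophenyl would compare with 2-chlorophenyl.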